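Oxazoline to thiazoline swap on a dichlorophenyl pyrazole sulfone

The source may report more compounds than this note shows. Statements on the series, on what has been measured and on what is new or still open speak of the compounds shown alone.

Compound 1 `O=S(=O)(CC1=NCCO1)c1c(-c2ccc(Cl)cc2)nn(-c2ccccc2)c1-c1ccc(Cl)cc1` is reported in a functional assay, tested at 50 ug/mL (on this read-out lower numbers stand for a weaker effect and higher numbers for a stronger effect at the one concentration tested), as "not active" (no number reported), with no number attached, so its standing on this read-out is known only as the absence of an effect. Among the measured compounds shown here, compound 2 `COc1ccc(-c2nn(-c3ccccc3)c(-c3ccc(C)cc3)c2S(=O)(=O)CC2=NCCO2)cc1` differs from compound 1 in several places at once; in this assay compound 2 gives 67.6%, and with no single step between the two, the pair shows only that one reads as active and the other does not. Compound 3 `O=S(=O)(CC1=NCCS1)c1c(-c2ccc(Cl)cc2)nn(-c2ccccc2)c1-c1ccc(Cl)cc1` carries a group of 5 heavy atoms (3 carbon, 1 nitrogen, 1 sulfur; one five-membered non-aromatic ring with 2 hetero atoms) in place of a group of 5 heavy atoms (3 carbon, 1 nitrogen, 1 oxygen; one five-membered non-aromatic ring with 2 hetero atoms), on a saturated chain carbon bound to a sulfonyl sulfur. For the measured compounds named here, no step from compound 1 to compound 3 has been measured, and nothing among the two measured compounds ties this assay to the ring next to the sulfonyl group. The expectation is therefore no step beyond the scatter, with compound 3 staying weak like compound 1. Compound 3 is estimated at 12% in this assay, within 0% to 35%, and a report of no activity without a number is about as likely as a figure.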

Compound 3, a percentage reported as activity, at one concentration (the size of the read-out at that concentration, not a potency): "not active" (no number reported)
Compound 3: no number reported; there is nothing to compare the estimate with.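

In this assay, compound 1 and compound 3 both carry no number, so no step can be read between them. From the compounds shown here alone, whether this ring exchange, on a saturated chain carbon bound to a sulfonyl sulfur, alters the read-out in a compound with measurable activity remains open. No supporting evidence bears on this result.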